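The source may hold more compounds than are shown below. What is called first, only, known or untested is meant among the compounds shown, and "the series" means these compounds.

Compound 1 `CC1CCN(C(=O)C(C)N2CCN(S(=O)(=O)c3ccc(C(C)(C)C)cc3)CC2)CC1` gives, in an ADME assay on HepG2 cells (Homo sapiens) for inhibition, with a stated time of 48 h (on this read-out lower numbers stand for an effect already at smaller amounts and higher numbers for an effect only at larger amounts of compound), a value that is a limit of the assay: > 40000 nM.
Compound 2 `CC(C(=O)N1CCC2(CC1)CC2)N1CCN(S(=O)(=O)c2ccc(C(C)(C)C)cc2)CC1` gives in this assay only a limit: > 40000 nM.
Compound 3 `CC(C(=O)N(C)Cc1ccccc1)N1CCN(S(=O)(=O)c2ccc(C(C)(C)C)cc2)CC1` gives in this assay only a limit: > 40000 nM.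

Compound 3 therefore stands nowhere on a numerical scale in this assay; it sits at the limit, as the limit of > 40000 nM in this assay, at which 3 of the 3 values shown sit, records for all three values. Compound 4 `CC(C(=O)N1CCc2ccccc2C1)N1CCN(S(=O)(=O)c2ccc(C(C)(C)C)cc2)CC1` differs from compound 3 by 1,2,3,4-tetrahydroisoquinolin-2-yl in place of benzyl(methyl)amino on a carbonyl carbon. The measured steps on the same carbonyl carbon bear on this change, but none can be read: a step that the two limits leave unreadable from compound 1 to compound 3, a step that the two limits leave unreadable from compound 2 to compound 3 and a step that the two limits leave unreadable from compound 1 to compound 2. No direction beyond the scatter can therefore be expected, and the step of a number no higher from compound 3 to compound 4 (the limit leaves the size open) is estimated to leave compound 4 near the limit. Compound 4 is expected to give 40000 nM, with a range from 15000 nM to 100000 nM.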

Compound 4, half-maximal effective concentration: 29000 nM
Estimate against measurement, compound 4: 1.4-fold (0.14 log units) above; measured number inside the range.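

Compound 4 is the only compound shown that gives a number rather than a limit in this assay, so a group on this carbonyl carbon now has one point on the scale. The steps are an at least 1.3-fold lower number from compound 3 to compound 4 (0.13 log units; that floor lies within the scatter), an at least 1.3-fold lower number from compound 2 to compound 4 (0.13 log units; that floor lies within the scatter) and an at least 1.3-fold lower number from compound 1 to compound 4 (0.13 log units; that floor lies within the scatter); each is only a floor, so no change beyond the scatter is shown. The steps among compound 1, compound 2 and compound 3 still cannot be read, and these compounds remain limits: the limit of > 40000 nM in this assay, at which 3 of the 4 values shown sit.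

From the compounds shown here alone, whether a 1,2,3,4-tetrahydroisoquinolin-2-yl group carrying an amine or a carboxylic acid would give a different number remains open.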